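This account rests on a few compounds, and the source may have more. Where it says the series, first, only, none or still open, it means among the compounds named here.

Measured compounds and their results:

Compound 1 `COc1cc2c(Oc3ccc(NC(=O)c4cc(-c5ccc(C)cc5)ccn4)cc3F)ccnc2cc1OCCCN1CCCC1` gives 440 nM in a functional assay on MKN-45 cells (Homo sapiens) for cytotoxicity, read by MTT assay, with a stated time of 72 h; on this read-out lower numbers stand for stronger inhibition and higher numbers for weaker inhibition.
Compound 2 `COc1cc2c(Oc3ccc(NC(=O)c4cc(-c5ccccc5C)ccn4)cc3F)ccnc2cc1OCCCN1CCCC1` gives 440 nM in this assay.
Compound 3 `COc1cc2c(Oc3ccc(NC(=O)c4cc(-c5ccccc5F)ccn4)cc3F)ccnc2cc1OCCCN1CCCC1` gives 230 nM in this assay.

Compound 3 has the lowest number of the three, but its separation from the others is slight: the step of a 1.9-fold lower number from compound 1 to compound 3 (0.28 log units; within the scatter) and the step of a 1.9-fold lower number from compound 2 to compound 3 (0.28 log units; within the scatter) both fall within the scatter of repeated measurements, so compound 3 cannot be called the most potent. Compound 4 `COc1ccc(-c2ccnc(C(=O)Nc3ccc(Oc4ccnc5cc(OCCCN6CCCC6)c(OC)cc45)c(F)c3)c2)c(OC)c1` has not yet been measured in this assay. It differs from compound 3 in one place: 2,4-dimethoxyphenyl in place of 2-fluorophenyl on an aromatic carbon. The measured steps that bear on this are all changes to the same aryl group on the shared core. The step of no change at the digits printed from compound 1 to compound 2 (within the scatter) and the step of a 1.9-fold lower number from compound 2 to compound 3 (0.28 log units; within the scatter) show that swapping a methyl for another methyl position, or a methyl for a fluoro, left the number essentially where it was. Among the compounds with values here, no measured step involves a methoxy group, so the data give no direct guidance on the entering 2,4-dimethoxyphenyl, which is a larger group with two hydrogen-bond acceptors. With three such changes all staying within the scatter, compound 4 is expected to show no step beyond the scatter, an expected step of a 1.5-fold higher number from compound 3 to compound 4 (0.18 log units; within the scatter). Compound 4 is therefore estimated at 350 nM in this assay, within a range of 120 nM to 1200 nM, with the range widened because the methoxy change lies outside anything measured.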

Compound 4, half-maximal inhibitory concentration: 740 nM
Compound 4: the middle estimate sits 2.1-fold (0.33 log units) below what was measured; the range from low to high includes it.
By their numbers in this assay, from the lowest: compounds 3, 1, 2 and 4 (each within the scatter of the next, the first and the last beyond it).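

In this assay, within the data shown here, replacing 2-fluorophenyl with 2,4-dimethoxyphenyl gives a 3.2-fold higher number from compound 3 to compound 4 (0.51 log units; beyond the scatter) and is the first measured change of this aryl group, opposite the ring nitrogen, to pass beyond the scatter, so the group at this position can shift the number measurably. The same entering group gives a 1.7-fold higher number from compound 2 to compound 4 (0.23 log units; within the scatter) and a 1.7-fold higher number from compound 1 to compound 4 (0.23 log units; within the scatter), both within the scatter, so 2,4-dimethoxyphenyl can be told apart only from 2-fluorophenyl and not from either methylphenyl group, and the effect of adding this group depends on which compound it is compared with. No measurement is available here that explains the difference between the 2-fluorophenyl and 2,4-dimethoxyphenyl compounds.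

The two methoxy groups enter together, so the compounds shown do not reveal whether a phenyl ring carrying a single methoxy group would give a similar step or whether both are needed. They also leave open how a phenyl ring carrying an amine or a carboxylic acid would read at this position, as neither group appears in these compounds.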